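Fluorine position on the benzylsulfanyl arm of compound 1

The compounds below may be only part of what the source reports. "The series", "measured", "known", "first", "only" and "open" are said of these compounds alone.

Compound 1, `COc1ccccc1/C=C(/SCc1ccc(F)cc1)C(=O)c1ccc(Cl)cc1`, is measured in a functional assay on DU-145 cells (Homo sapiens) for inhibition, read by trypan blue exclusion, with a stated time of 96 h (a higher number here means a weaker inhibitor of growth, a lower number a stronger inhibitor of growth), where compound 1 gives 10000 nM. Compound 3, `COc1ccccc1/C=C(/SCc1ccc(F)cc1)C(=O)c1ccc(Br)cc1`, gives 10000 nM in this assay, and the step of no change at the digits printed from compound 1 to compound 3 (within the scatter), bromo in place of chloro on an aromatic carbon, leaves the number as it was. Compound 2, `CN(C)c1ccc(/C=C(/SCc2ccc(F)cc2)C(=O)c2ccc(Cl)cc2)cc1`, gives 50000 nM; the step of a 5.0-fold higher number from compound 1 to compound 2 (0.70 log units; beyond the scatter) is the only one in this set that moves the number beyond the scatter. Compound 1 therefore stands level with compound 3 at the low end of the three numbers, with compound 2 furthest away.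

Compound 4, `COc1ccccc1/C=C(/SCc1ccccc1F)C(=O)c1ccc(Cl)cc1`, differs from compound 1 only in 2-fluorophenyl in place of 4-fluorophenyl on a saturated chain carbon bound to a sulfur. Neither measured step touches this part of the structure: one alters the aryl group on the chain, the other the halogen on the ketone-bearing ring. No measured change bears directly on the fluorobenzyl group, so the expectation for compound 4 is a step of no change at the digits printed from compound 1 to compound 4 (within the scatter), within the scatter. Compound 4 is thus estimated at 10000 nM, with a range from 4000 nM to 25000 nM.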

Compound 4, concentration for 50% growth inhibition: 10000 nM
Compound 4: middle estimate and measured number agree at the digits printed; the range from low to high includes it.
By their numbers in this assay, from the lowest: compounds 1, 3 and 4 (each within the scatter of the next); then compound 2.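

In this assay, among the compounds shown here, the change to 2-fluorophenyl in place of 4-fluorophenyl on a saturated chain carbon bound to a sulfur gives no change at the digits printed from compound 1 to compound 4 (within the scatter) and is the first reading on the fluorobenzyl arm. The earlier steps shown here covered only the aryl group on the chain and the halogen on the other ring, so this is new information: with the core of compound 1 held fixed, 2-fluorobenzyl and 4-fluorobenzyl cannot be told apart in this read-out. No supporting measurement is available to account for this result.

Going by these compounds, it remains open whether the arm is as undemanding towards a different group, such as a carboxylic acid on its ring or a longer chain in place of benzyl. On these data alone, it also remains open whether the 2-fluorobenzyl change reads the same alongside the bromo group of compound 3 or the 4-(dimethylamino)phenyl group of compound 2.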